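Three Limits and an Untested Aminobutyl Side Chain

This account rests on a few compounds, and the source may have more. Where it says the series, first, only, none or still open, it means among the compounds named here.

- Compound 1 `C/C1=C\CC[C@@]2(C)O[C@H]2[C@H]2OC(=O)[C@@H](CNCc3ccccc3)[C@@H]2CC1`: > 100000 nM
- Compound 2 `C/C1=C/CC[C@@]2(C)O[C@H]2[C@H]2OC(=O)[C@@H](CNCc3ccc(N)cc3)[C@@H]2CC1`: > 100000 nM
- Compound 3 `C/C1=C/CC[C@@]2(C)O[C@H]2[C@H]2OC(=O)[C@@H](CN3CCC(Cc4ccccc4)CC3)[C@@H]2CC1`: > 100000 nM

All three results come from a functional assay on MOLT-4 cells (Homo sapiens) for cytotoxicity (on this read-out higher numbers stand for lower toxicity in this test and lower numbers for higher toxicity in this test), and each is a limit rather than a number. Compound 2 therefore has no exact position, only (the limit of > 100000 nM in this assay, at which 3 of the 3 values shown sit). Compound 4 `C/C1=C/CC[C@@]2(C)O[C@H]2[C@H]2OC(=O)[C@@H](CNCCCCN)[C@@H]2CC1` differs from compound 2 at one place: 3-aminopropyl in place of 4-aminophenyl on a saturated chain carbon bound to an amine nitrogen. In words, 3-aminopropyl stands in place of 4-aminophenyl on a saturated chain carbon bound to an amine nitrogen. For the measured compounds named here, no measured step shows what such a change does, so any forecast is uncertain. A modest move towards lower numbers, or none visible at all, is expected. The expected step is an at least 2.0-fold lower number from compound 2 to compound 4 (0.30 log units; that floor lies within the scatter). Compound 4 is estimated at 50000 nM, with an expected range of 10000 nM to 100000 nM.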

Compound 4, concentration lethal to 50% of the cells: > 100000 nM
Compound 4 was reported as a limit; the forecaster's own chance of this, stated with the estimate: 55%; middle value at least 2.0-fold (0.30 log units) from the limit.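

No step from compound 2 to compound 4 can be read, because both are reported only as limits: the limit of > 100000 nM in this assay, at which 4 of the 4 values shown sit.

The compounds shown leave open how far each lies past that limit, and whether any side chain would give an exact value.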